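This account rests on a few compounds, and the source may have more. Where it says the series, first, only, none or still open, it means among the compounds named here.

Measured compounds in an assay on cells for inhibition of Indoleamine 2,3-dioxygenase 1 (Homo sapiens), read by HPLC, with a stated time of 20 min; on this read-out lower numbers stand for stronger inhibition and higher numbers for weaker inhibition:
Compound 1 `Cn1cncc1-c1ccccc1N` gives 1700000 nM.
Compound 2 `Nc1ccc(Cl)cc1-n1ccnc1` gives 88000 nM.
Compound 3 `Oc1ccccc1-c1nnc[nH]1` gives 31000 nM.

Compound 3 has the lowest number of the three. Its nearest neighbour is compound 2, whose number is higher by an amount beyond the scatter, and compound 1 lies much further off. Compound 4 `Nc1ccccc1-c1nnc[nH]1` is not yet measured. It differs from compound 3 by amino in place of hydroxy on an aromatic carbon; the rest of the structure is kept.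

Going by the values given here, no measured pair shows this change on this core, so no step is available to lean on. Compounds 1 and 2 both carry an amino group on the six-membered ring, but their other ring differs from that of compound 3, and their values in this assay cannot be read as a step for this change. The expectation for the step from compound 3 to compound 4 is therefore a small rise in the number, close to the scatter, with wide uncertainty: a 1.9-fold higher number from compound 3 to compound 4 (0.29 log units; within the scatter). Compound 4 is accordingly estimated at 60000 nM, in the range from 15000 nM to 250000 nM in this assay.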

Compound 4, half-maximal inhibitory concentration: 2000 nM
For compound 4 the middle estimate is 30-fold (1.48 log units) above the measured one; the whole stated range lies above it.
By their numbers in this assay, from the lowest: compound 4; then compound 3; then compound 2; then compound 1.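

Going by these compounds alone, on the shared core, amino in place of hydroxy on an aromatic carbon gives a 16-fold lower number from compound 3 to compound 4 (1.19 log units; beyond the scatter) in this assay and so supplies the first readable step, showing that the number at this place depends strongly on which of the two groups is present. The two groups match in what is counted, each having one heavy atom, one hydrogen-bond donor and one hydrogen-bond acceptor with no net charge, so these counts do not separate them. Nothing in hand accounts for the size of the step. On these data alone, how a methylamino, acetamido or fluoro group would read at this same place remains open. Also open, as far as these compounds go, is whether the same exchange gives a step of similar size on the cores of compound 1 and compound 2.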